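This account rests on a few compounds, and the source may have more. Where it says the series, first, only, none or still open, it means among the compounds named here.

Compound 1 `Fc1ccc(CN2CCC(NCCSC(c3ccc(F)cc3)c3ccc(F)cc3)CC2)cc1` has the lower of the two numbers recorded here. In an assay on membranes from striatum (strain Sprague-Dawley) for displacement of a labelled ligand from sodium-dependent dopamine transporter (Rattus norvegicus), read by scintillation counting, with a stated time of 120 min (on this read-out higher numbers stand for weaker inhibition and lower numbers for stronger inhibition), compound 1 gives 25.5 nM. Compound 2 `[O-][S+](CCNC1CCN(CC(O)Cc2ccccc2)CC1)C(c1ccc(F)cc1)c1ccc(F)cc1` stands at a higher number, beyond the usual scatter: in this assay compound 2 gives 91.8 nM. Among the measured compounds shown here, no step between measured compounds that differ in only one place is available, and compound 2 differs from compound 1 in more than one place, so its number only shows where a second member of the series falls.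

Compound 3 `O=C(c1ccccc1)N1CCC(NCCSC(c2ccc(F)cc2)c2ccc(F)cc2)CC1` has not yet been measured. It differs from compound 1 in one place: benzoyl in place of 4-fluorobenzyl on an amine nitrogen in a ring. For the measured compounds named here, nothing among the measured compounds isolates this change, so the expectation rests on compound 1 alone and on the size of the change. The expected step is a 12-fold higher number from compound 1 to compound 3 (1.07 log units; beyond the scatter), a move toward a weaker result that is expected to lie beyond the scatter. In this assay compound 3 is estimated at 300 nM, with a range expected from 60 nM to 1500 nM.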

Compound 3, inhibition constant: 4.51 nM
The estimate for compound 3 lay 67-fold (1.82 log units) above the measured number; measured number below the stated range.
By their numbers in this assay, from the lowest: compound 3; then compound 1; then compound 2.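

At this place, on an amine nitrogen in a ring, 4-fluorobenzyl is not needed for a low number in this assay: benzoyl, with the same count of heavy atoms and one hydrogen-bond acceptor where 4-fluorobenzyl has none, gives a 5.7-fold lower number from compound 1 to compound 3 (0.75 log units; beyond the scatter), a modest step beyond the scatter. The change alters two things at once, since the fluorine leaves the group and a carbonyl enters it, and this single pair cannot assign the step to either one. No measurement is available that explains the direction or size of this step.

As far as these compounds go, it remains open whether the step follows the carbonyl or the loss of the fluorine, a question that 4-fluorobenzoyl or unsubstituted benzyl at the same nitrogen would help to separate. The compounds shown also leave open whether the lower number extends to other groups at this place, such as acetyl or benzenesulfonyl, and whether it would hold on a different core.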